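The compounds below may be only part of what the source reports. "The series", "measured", "known", "first", "only" and "open" are said of these compounds alone.

The series is followed in a functional assay on HEK293 cells for agonist activity at Toll-like receptor 8 (Homo sapiens), read by reporter gene assay; a higher number here means that more compound is needed for the effect, a lower number that less compound is needed. Compound 1 `Cc1ncc(CO)c(-c2nc3ccccn3c2NC2CCCCC2)c1OCc1ccccc1` returns "not active" (no number reported) in this assay. Compound 2 `CCCCCNc1oc2c(C)ncc(CO)c2c1Nc1ccccn1` gives 5810 nM in this assay, and compound 3 `CCCCNc1oc2c(C)ncc(CO)c2c1Nc1ccccn1` gives 9380 nM in this assay. For the measured compounds named here, the one single-change step available runs a 1.6-fold higher number from compound 2 to compound 3 (0.21 log units; within the scatter), so compound 2 and compound 3 sit together on the two numbers in hand, with compound 1 beside them without a number.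

Compound 4 `CCCCCNc1oc2c(C)ncc(CO)c2c1Nc1cccc([N+](=O)[O-])c1` differs from compound 2 in one place: 3-nitrophenyl in place of pyridin-2-yl on a nitrogen on an aromatic ring. Going by the values given here, no measured step touches this nitrogen; the only step, from compound 2 to compound 3, alters the saturated chain and stays within the scatter. Nothing measured therefore points to a shift in either direction in this assay, and the expectation for compound 4 rests on compound 2 alone, whose value of 5810 nM serves as the anchor with a broad margin.

Compound 4 is expected near 7000 nM in this assay, with a range of 1500 nM to 40000 nM. This estimate corresponds to an expected step of a 1.2-fold higher number from compound 2 to compound 4 (0.08 log units; within the scatter).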

Compound 4, half-maximal effective concentration: 850 nM
For compound 4 the middle estimate is 8.2-fold (0.92 log units) above the measured one; the whole stated range lies above it.
By their numbers in this assay, from the lowest: compound 4; then compounds 2 and 3 (each within the scatter of the next).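

For the compounds shown here, the group on the nitrogen on an aromatic ring is the first place where a single change moves the number in this assay beyond the scatter, with a 6.8-fold lower number from compound 2 to compound 4 (0.83 log units; beyond the scatter) on going from pyridin-2-yl to 3-nitrophenyl. Going by these compounds alone, the only earlier step, on the saturated chain (a 1.6-fold higher number from compound 2 to compound 3 (0.21 log units; within the scatter)), gave no such separation, so this nitrogen substituent is the more responsive of the two places examined so far. No measurement available here bears on the reason for the lower number.

This one step replaces the ring with a hetero atom and adds the nitro group together, so the compounds shown leave open which of the two goes with the lower number. An unsubstituted phenyl or a 3-aminophenyl on this nitrogen would separate them.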